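The compounds below may be only part of what the source reports. "The series", "measured", "known", "first", "only" and "open" are said of these compounds alone.

Three compounds have been measured in a functional assay on MCF7 cells (Homo sapiens) for antiproliferative activity, read by MTT assay, with a stated time of 24 h, tested at 50 uM; on this read-out lower numbers stand for a stronger effect and higher numbers for a weaker effect at the one concentration tested:
compound 3 `OC(CCn1nc2c(Br)c(Br)c(Br)c(Br)c2n1)c1ccc(Br)cc1` gives 10%;
compound 1 `OC(CCn1nc2c(Br)c(Br)c(Br)c(Br)c2n1)c1ccc(F)cc1` gives 16%;
compound 2 `C[C@@H](O)CCn1nc2c(Br)c(Br)c(Br)c(Br)c2n1` gives 102%.

Compound 3 stands lowest of the three numbers, with compound 1 nearest and within the scatter of it, and compound 2 far above it, beyond the scatter. For the measured compounds named here, the only measured step between single-point neighbours is a number 6 percentage points lower from compound 1 to compound 3 (within the scatter), which swaps one halogen for another on the aromatic ring and says nothing about removing that ring altogether.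

Compound 4 `CC(O)CCn1nc2c(Br)c(Br)c(Br)c(Br)c2n1` has not yet been measured. It differs from compound 3 in one place: methyl in place of 4-bromophenyl on a saturated chain carbon bound to an oxygen on a saturated carbon and a saturated chain carbon. Going by the values given here, no measured step covers this change directly. Compound 2, however, carries a methyl at the same place and gives a high number, while compound 3 with its 4-bromophenyl gives a low one; these two values alone suggest that compound 4 should sit close to compound 2.

Compound 4 is therefore expected to give about 98%, between 82% and 110%. The expected change is a number 88 percentage points higher from compound 3 to compound 4 (beyond the scatter), a large rise well beyond the scatter.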

Compound 4, a percentage reported as activity, at one concentration (the size of the read-out at that concentration, not a potency): 90%
Estimate against measurement, compound 4: 8 percentage points above; low and high end bracket the measured number.
By their numbers in this assay, from the lowest: compounds 3 and 1 (each within the scatter of the next); then compound 4; then compound 2.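

In this assay the change from an aromatic group to methyl at this place is now measured directly, and it is large from either aromatic compound (a number 80 percentage points higher from compound 3 to compound 4 (beyond the scatter); a number 74 percentage points higher from compound 1 to compound 4 (beyond the scatter)). The low numbers of compound 3 and compound 1 are therefore lost when 4-bromophenyl or 4-fluorophenyl gives way to methyl on this saturated chain carbon. Compound 2 and compound 4 share the same atoms and bonds, yet a modest step separates them (a number 12 percentage points lower from compound 2 to compound 4 (beyond the scatter)), and one difference goes with it: the fact that one of compounds 2 and 4 is drawn with a defined configuration and the other without, at the place where they differ.

On these data alone, what the opposite configuration alone would give stays open, as compound 4 is drawn without one. Also open, as far as these compounds go, is whether an unsubstituted phenyl, a longer chain or an amine at this place would give a low number or a high one.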